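The source may report more compounds than this note shows. Statements on the series, on what has been measured and on what is new or still open speak of the compounds shown alone.

Among the compounds with values here, in a functional assay on A2780 cells (Homo sapiens) for inhibition, read by sulforhodamine B assay (a lower number here means a stronger inhibitor of growth, a higher number a weaker inhibitor of growth), two compounds have numbers so far. Compound 1 `COc1cc(-c2ccc(-c3ccc(-c4nc5cc(C)ccc5[nH]4)cc3)cc2)cc(OC)c1OC` gives 190 nM, while compound 2 `COc1ccc(-c2ccc(-c3ccc(-c4nc5c(O)cccc5[nH]4)cc3)cc2)cc1OC` gives 2710 nM. Compound 2 thus holds the higher of the two numbers and is the weaker inhibitor of growth, and the gap between the two lies beyond the usual scatter. Compound 3 `COc1cc(-c2ccc(-c3ccc(-c4nc5c(O)cccc5[nH]4)cc3)cc2)cc(OC)c1OC` departs from compound 2 in one place: methoxy in place of hydrogen on an aromatic carbon. Within the data shown here, no measured pair shows this change on its own, so the data offer no direct precedent for its size. Compound 3 does share its set of methoxy groups with compound 1, which stands at 190 nM, but it keeps the rest of compound 2. A moderate move toward lower numbers in this assay is therefore expected, probably beyond the scatter, though not all the way to the value of compound 1. The estimate amounts to an expected 3.4-fold lower number from compound 2 to compound 3 (0.53 log units; beyond the scatter). For compound 3 the estimated value is 800 nM, with an expected range from 200 nM to 2800 nM.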

Compound 3, concentration for 50% growth inhibition: 170 nM
Compound 3: middle estimate off by 4.7-fold (0.67 log units), on the high side; measured number outside the range, below it.
By their numbers in this assay, from the lowest: compounds 3 and 1 (each within the scatter of the next); then compound 2.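

The methoxy in place of hydrogen, on an aromatic carbon ortho to a methoxy group and meta to a large group, proves to be a decisive single change in this assay, giving a 16-fold lower number from compound 2 to compound 3 (1.20 log units; beyond the scatter), a large step for a group of only 2 heavy atoms. Once this methoxy is present, 4-hydroxy-1H-benzimidazol-2-yl in place of 5-methyl-1H-benzimidazol-2-yl gives only a 1.1-fold lower number from compound 1 to compound 3 (0.05 log units; within the scatter). Nothing at hand explains why this one methoxy carries so much weight.

The compounds shown leave open whether methoxy itself is needed on this aromatic carbon, or whether a hydroxy group, an ethoxy group or a chlorine atom would serve there as well. Within the data shown here, they also leave open whether the same methoxy step would be as large in a compound carrying 5-methyl-1H-benzimidazol-2-yl, since the step has been seen only with the 4-hydroxy-1H-benzimidazol-2-yl group.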